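Bromohydroxyphenyl expected to recover what hydroxypyridinyl lost

The source may hold more compounds than are shown below. What is called first, only, known or untested is meant among the compounds shown, and "the series" means these compounds.

Compound 2 `O=C1Nc2ccc(C(=O)c3ccco3)cc2/C1=C/c1ccc(O)nc1` stands lowest of the two numbers in an assay on HeLa cells for inhibition of Kinesin-like protein KIF15 (Homo sapiens), read by microscopy, with stated times of 2 s and 20 s, tested at 750 nM; on this read-out higher numbers stand for more inhibition at the one concentration tested (going by the name of the read-out) and lower numbers for less inhibition: compound 2 gives 26.5%, while compound 1 `O=C1Nc2ccc(C(=O)c3ccco3)cc2/C1=C/c1cc(F)c(O)c(Br)c1` gives 38%. For the measured compounds named here, the single measured step, a number 11.5 percentage points lower from compound 1 to compound 2 (beyond the scatter), lies beyond the scatter. Compound 3 `O=C1Nc2ccc(C(=O)c3ccco3)cc2/C1=C/c1ccc(O)c(Br)c1` carries 3-bromo-4-hydroxyphenyl in place of 6-hydroxypyridin-3-yl on a double-bonded chain carbon bound to a double-bonded ring carbon. Compound 3 thus holds the bromine and hydroxyl of compound 1 without its fluorine, so a rise of roughly the size of a number 11.5 percentage points lower from compound 1 to compound 2 (beyond the scatter) is expected in reverse. Compound 3 is estimated at 36% (range 24% to 48%), an expected step of a number 9.5 percentage points higher from compound 2 to compound 3 (within the scatter).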

Compound 3, a percentage reported as inhibition, at one concentration (the size of the read-out at that concentration, not a potency): 23%
Estimate against measurement, compound 3: 13 percentage points above; the measured number lies below the stated range.
By their numbers in this assay, from the lowest: compounds 3 and 2 (each within the scatter of the next); then compound 1.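

In this assay, 3-bromo-4-hydroxyphenyl in place of 6-hydroxypyridin-3-yl gives a number 3.5 percentage points lower from compound 2 to compound 3 (within the scatter), so at this position the two groups are not separated by this read-out. Hydrogen in place of fluoro on an aromatic carbon gives a number 15 percentage points lower from compound 1 to compound 3 (beyond the scatter), so among these compounds the fluoro, not the bromine alone, marks the difference. No measurement on hand accounts for this result.

Going by these compounds, whether chloro or methoxy in place of that fluoro would hold the number of compound 1 remains open, as does the effect of the fluoro without the bromine.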